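Swapping the Side Chain on a Core Without a Number

The compounds below may be only part of what the source reports. "The series", "measured", "known", "first", "only" and "open" are said of these compounds alone.

Compound 1 `COc1cc(OC)c(-c2coc3cc(OCC(=O)c4cccc(C(F)(F)F)c4)ccc3c2=O)cc1OC` is known only through a limit: in a functional assay on HCT-116 cells (Homo sapiens) for antiproliferative activity, read by MTT assay, with a stated time of 24 h (on this read-out lower numbers stand for stronger inhibition and higher numbers for weaker inhibition), compound 1 gives > 10000 nM, a limit of the assay rather than a number. Compound 2 `COc1cc(OC)c(-c2coc3cc(OCc4ccccc4C#N)ccc3c2=O)cc1OC` likewise gives only a limit, > 10000 nM, in this assay. The step that the two limits leave unreadable from compound 1 to compound 2 therefore cannot be read, and the limit of > 10000 nM in this assay, at which 2 of the 2 values shown sit, is all the evidence there is. Compound 3 `COc1cc(OC)c(-c2coc3cc(OCc4ccccc4Br)ccc3c2=O)cc1OC` differs from compound 1 in one place: 2-bromophenyl in place of (3-(trifluoromethyl)phenyl)carbonyl on a saturated chain carbon bound to an oxygen on an aromatic ring. With no readable step to lean on, the expected step is a step that the limit leaves unreadable from compound 1 to compound 3. Compound 3 is therefore estimated at 15000 nM, with a range from 3000 nM to 60000 nM.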

Compound 3, half-maximal inhibitory concentration: 4550 nM
The estimate for compound 3 lay 3.3-fold (0.52 log units) above the measured number; low and high end bracket the measured number.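

Within the data shown here, compound 3 gives the first real number in this assay, so a change on a saturated chain carbon bound to an oxygen on an aromatic ring can now be read: 2-bromophenyl in place of (3-(trifluoromethyl)phenyl)carbonyl gives an at least 2.1-fold lower number from compound 1 to compound 3 (0.34 log units; beyond the scatter) on the shared core. Bromo in place of cyano on an aromatic carbon gives an at least 2.1-fold lower number from compound 2 to compound 3 (0.34 log units; beyond the scatter) and so a single atom-level swap is enough to leave the limit. Both steps are minimum sizes, and the step between compound 1 and compound 2 cannot be read: the limit of > 10000 nM in this assay, at which 2 of the 3 values shown sit.

On these data alone, whether a chloro group or an amine in place of the bromo would give a lower number stays open.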